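A few compounds are considered here, and "the series" means these few. Any claim that something is new, unique, unknown or untested is made for them only; others in the source may bear on it.

Compound 1: `CN1CC[C@H](c2ccc(Cl)cc2)[C@@H](C(=O)OCCCCCc2ccccc2)C1`, 382 nM
Compound 2: `CCOC(=O)C[C@H]1CN(C)CC[C@@H]1c1ccc(Cl)cc1`, 101 nM
Compound 3: `CN1CC[C@H](c2ccc(Cl)cc2)[C@@H](CCC(=O)Nc2ccccc2)C1`, 56 nM

All three compounds share one core and were tested in an assay on Cortex with Norepinephrine transporter (Rattus norvegicus) as the target; a lower number here means a stronger inhibitor, a higher number a weaker inhibitor. Compound 2 stands second highest of the three numbers. Its nearest neighbour is compound 3, whose value of 56 nM lies within the scatter of repeated measurements, so the two cannot be told apart. Compound 1, with 382 nM, sits higher than compound 2 by a margin beyond the scatter, so compound 1 is the weaker of those two.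

Compound 4, `CN1CC[C@H](c2ccc(Cl)cc2)[C@@H](CCCF)C1`, has not yet been measured in this assay. It differs from compound 2 in one place: 2-fluoroethyl in place of ethoxycarbonyl on a saturated chain carbon bound to a saturated ring carbon. Among the measured compounds shown here, no pair of measured compounds shows this kind of change, so there is no measured step to lean on. The expected step from a 1.5-fold higher number from compound 2 to compound 4 (0.17 log units; within the scatter) is modest, with a slight lean toward a higher number, but it may well stay within the scatter. Compound 4 is therefore expected to give roughly 150 nM in this assay, with a plausible range from 45 nM to 500 nM.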

Compound 4, inhibition constant: 356 nM
For compound 4 the middle estimate is 2.4-fold (0.38 log units) below the measured one; the range from low to high includes it.
By their numbers in this assay, from the lowest: compounds 3 and 2 (each within the scatter of the next); then compounds 4 and 1 (each within the scatter of the next).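

At this place, on a saturated chain carbon bound to a saturated ring carbon, the position does respond to the group it carries: in this assay, 2-fluoroethyl in place of ethoxycarbonyl gives a 3.5-fold higher number from compound 2 to compound 4 (0.55 log units; beyond the scatter) and so a weaker inhibitor. The change replaces a larger group holding a double bond and two hydrogen-bond acceptors with a smaller one holding neither, and this single step cannot separate those differences. Nothing measured here explains the shift.

Still open, on these data alone, is whether the weakening follows from removing the ester or from adding the fluorine. A plain propyl chain, a 3-hydroxypropyl chain or a carboxylic acid at this place would help to tell these apart.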